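Bulkier isoxazole substituent on a pyrazolopyrimidine-free core

The compounds below may be only part of what the source reports. "The series", "measured", "known", "first", "only" and "open" are said of these compounds alone.

Measured compounds in an ADME assay on Nthy-ori 3-1 cells (Homo sapiens) for cytotoxicity, read by MTT assay, with a stated time of 10 days; a lower number here means a stronger inhibitor of growth, a higher number a weaker inhibitor of growth:
compound 1 `CCc1cc(-c2nn(C(C)C)c3ncnc(N)c23)no1` gives 28600 nM
compound 2 `CCCCCCCn1nc(-c2cc(C3CC3)on2)c2c(N)ncnc21` gives 31600 nM
compound 3 `CC(C)(O)Cn1nc(-c2cc(C3CC3)on2)c2c(N)ncnc21` gives 2820 nM

Compound 1 stands second highest of the three numbers; compound 2 lies within the scatter of it, while compound 3 sits well below both. Among the compounds with values here, the only step between measured compounds is an 11-fold lower number from compound 2 to compound 3 (1.05 log units; beyond the scatter), and it concerns the group on the saturated chain carbon bound to the aromatic nitrogen, not the five-membered aromatic ring. Compound 4 `CC(C)n1nc(-c2cc(C(C)(C)C)on2)c2c(N)ncnc21` differs from compound 1 elsewhere: tert-butyl in place of ethyl on an aromatic carbon. Within the data shown here, no measured step touches that position, so the change from compound 1 to compound 4 has to be judged without a direct precedent. Compounds 1 and 2, which carry different groups at that position among other differences, give numbers within the scatter of each other. The expected step is therefore a 1.0-fold higher number from compound 1 to compound 4 (0.02 log units; within the scatter), none beyond the scatter. Compound 4 is estimated at 30000 nM, with a range from 12000 nM to 75000 nM.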

Compound 4, concentration for 50% growth inhibition: 24700 nM
Compound 4: middle estimate off by 1.2-fold (0.08 log units), on the high side, within the range that was stated.
By their numbers in this assay, from the lowest: compound 3; then compounds 4, 1 and 2 (each within the scatter of the next).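

In this assay, within the data shown here, tert-butyl in place of ethyl on the aromatic carbon next to the ring oxygen gives a 1.2-fold lower number from compound 1 to compound 4 (0.06 log units; within the scatter) and so provides the first direct reading at this position: the two numbers cannot be told apart, although tert-butyl has 4 heavy atoms and ethyl 2. Between these two groups, this position therefore shows no measurable difference, whereas the one large step shown, an 11-fold lower number from compound 2 to compound 3 (1.05 log units; beyond the scatter), lies on the saturated chain carbon bound to the aromatic nitrogen. No measurement shown here bears on why ethyl and tert-butyl read alike. Ethyl and tert-butyl hold only carbon, so it remains open whether an amine or a carboxylic acid at this carbon would give a step beyond the scatter. Also open, going by these compounds, is whether 1-hydroxy-1-methylethyl on the chain would lower the number on the core of compound 4.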